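Replacing the thiazolyl ethenyl arm of compound 3 with a biaryl

The source may report more compounds than this note shows. Statements on the series, on what has been measured and on what is new or still open speak of the compounds shown alone.

Of the compounds shown here, three have been measured in an assay on isolated protein with Bile acid receptor (Homo sapiens) as the target; a higher number here means that more compound is needed for the effect, a lower number that less compound is needed. Compound 1 `COC(=O)/C=C/c1cccc(N(Cc2ccc(/C=C/c3c(Cl)cccc3Cl)cc2)C(=O)C(C)C)c1` gives 195 nM, compound 2 `COC(=O)/C=C/c1cccc(N(Cc2ccc(/C=C/c3cccc(F)c3)cc2)C(=O)C(C)C)c1` gives 71 nM, and compound 3 `COC(=O)/C=C/c1cccc(N(Cc2ccc(/C=C/c3scnc3C)cc2)C(=O)C(C)C)c1` gives 228 nM. Compound 3 has the highest number of the three, but its gap to compound 1 is within the scatter, while the step of a 3.2-fold higher number from compound 2 to compound 3 (0.51 log units; beyond the scatter) is beyond it; the step of a 2.7-fold lower number from compound 1 to compound 2 (0.44 log units; beyond the scatter) is of similar size in the other direction.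

Compound 4 `COC(=O)/C=C/c1cccc(N(Cc2ccc(-c3cc(Cl)ccc3OC)cc2)C(=O)C(C)C)c1` differs from compound 3 in that (5-chloro-2-methoxyphenyl in place of 2-(4-methyl-1,3-thiazol-5-yl)ethenyl on an aromatic carbon). Every measured step exchanged only the aryl group at the far end of the ethenyl linker; none removed the linker itself or brought a ring directly onto the aromatic carbon of the core. The measured steps therefore bear on the new compound only loosely, showing that such changes at this end of the molecule have moved the number by modest amounts in either direction.

On that basis a modest step is expected, and, with the linker gone, a somewhat higher number is estimated for compound 4, a 1.3-fold higher number from compound 3 to compound 4 (0.12 log units; within the scatter), putting it at 300 nM with a range from 90 nM to 1000 nM.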

Compound 4, half-maximal effective concentration: 226 nM
Estimate against measurement, compound 4: 1.3-fold (0.12 log units) above; the range from low to high includes it.
By their numbers in this assay, from the lowest: compound 2; then compounds 1, 4 and 3 (each within the scatter of the next).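

In this assay, within the data shown here, the earlier steps only exchanged the aryl group at the far end of the ethenyl linker, whereas this change removes the linker and puts 5-chloro-2-methoxyphenyl directly on the aromatic carbon, para to a large group; a 1.0-fold lower number from compound 3 to compound 4 (0.00 log units; within the scatter) shows a difference within the scatter, and a 1.2-fold higher number from compound 1 to compound 4 (0.06 log units; within the scatter) likewise stays within it. The position therefore accepts a directly attached ring without a difference that can be told from the scatter against these two ethenyl compounds, but a 3.2-fold higher number from compound 2 to compound 4 (0.50 log units; beyond the scatter) lies beyond the scatter, so the new compound does not match the 3-fluorophenyl ethenyl arm of compound 2. Nothing at hand explains any of these numbers.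

Compound 4 differs from the others in both its linker and its ring, so the compounds shown cannot separate the loss of the ethenyl linker from the change of aryl group. Going by these compounds, it also stays open whether a 3-fluorophenyl ring attached directly to the aromatic carbon would keep the number of compound 2, and how an amine or a carboxylic acid on the new ring would read in this assay.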